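From 3-fluorophenyl to 3,4-difluorophenyl in compound 3

A few compounds are considered here, and "the series" means these few. Any claim that something is new, unique, unknown or untested is made for them only; others in the source may bear on it.

Values measured so far in a functional assay on HT-29 cells (Homo sapiens) for antiproliferative activity, read by sulforhodamine B assay, with a stated time of 48 h (a lower number here means a stronger inhibitor, a higher number a weaker inhibitor), are these
compound 1 `CCCN1CCN(c2ccc(S(=O)(=O)Oc3cccc(F)c3)cc2)C1=O` gives 18000 nM
compound 2 `CCCCN1CCN(c2ccc(S(=O)(=O)Oc3ccccc3)cc2)C1=O` gives > 100000 nM
compound 3 `CCCCN1CCN(c2ccc(S(=O)(=O)Oc3cccc(F)c3)cc2)C1=O` gives 76000 nM

Compound 2 gives > 100000 nM, which is a limit of the assay and not a number. Of the two true numbers, the higher belongs to compound 3, which makes it the weaker inhibitor of that pair. The gap is a 4.2-fold higher number from compound 1 to compound 3 (0.63 log units; beyond the scatter), but that step lies in the chain and not on the aromatic ring.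

Compound 4 `CCCCN1CCN(c2ccc(S(=O)(=O)Oc3ccc(F)c(F)c3)cc2)C1=O` differs by a single change, (fluoro in place of hydrogen on an aromatic carbon), which turns 3-fluorophenyl into 3,4-difluorophenyl. Among the compounds with values here, the closest precedent is the same kind of replacement, fluoro in place of hydrogen on an aromatic carbon, seen in an at least 1.3-fold lower number from compound 2 to compound 3 (0.11 log units; that floor lies within the scatter). That one step gives only a weak guide, so no step beyond the scatter is expected in this assay, with a slight lean towards a lower number. The estimated change is a 1.4-fold lower number from compound 3 to compound 4 (0.14 log units; within the scatter). For compound 4 the expected value is 55000 nM, with an estimated range of 25000 nM to 100000 nM.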

Compound 4, half-maximal inhibitory concentration: > 100000 nM
Compound 4: no number, only a limit (the forecaster's own chance of this, stated with the estimate: 20%); at least 1.8-fold (0.25 log units) between middle value and limit.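

In this assay compound 4 gives > 100000 nM, which is a limit of the assay and not a number. The second fluoro, on the aromatic carbon ortho to a fluoro group and para to a large group, gives an at least 1.3-fold higher number from compound 3 to compound 4 (0.11 log units; that floor lies within the scatter), so this position brings no readable gain in strength, though the step is too small to count as a real loss. The step from compound 2 to compound 4 cannot be read because both values are limits, which also leaves little room to rank these ring changes: the limit of > 100000 nM in this assay, at which 2 of the 4 values shown sit.

The compounds shown leave open whether a different group at this position, such as methoxy or an amine, would bring the number clearly below the limit. They also leave open whether 3,4-difluorophenyl would give a readable number on the chain of compound 1.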